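A few compounds are considered here, and "the series" means these few. Any claim that something is new, unique, unknown or untested is made for them only; others in the source may bear on it.

Four compounds share one core, in which a branched ketone and a hydroxyl sit on an aromatic ring that is tied through a chain to a second aromatic ring carrying a carboxylic acid. Compound 1 `COC(=O)c1ccc(OCCCCOc2ccc(C(=O)CC(C)C)c(O)c2C)cc1` carries a methyl ester instead of the free acid, and in an assay on HEK293 cells for positive allosteric modulation of metabotropic glutamate receptor 2 (Rattus norvegicus), read by thallium flux, with a stated time of 2.5 min (on this read-out lower numbers stand for an effect already at smaller amounts and higher numbers for an effect only at larger amounts of compound), compound 1 gives "not determined" (no result reported), no result having been reported. Compound 2 `Cc1ccc(C(=O)O)cc1OCCCCOc1ccc(C(=O)CC(C)C)c(O)c1C` gives 454 nM in this assay. Among the measured compounds shown here, compound 3 `Cc1c(OCCCCOc2cccc(C(=O)O)c2)ccc(C(=O)CC(C)C)c1O` gives 222 nM, the lowest of the two numbers recorded, and the step of a 2.0-fold lower number from compound 2 to compound 3 (0.31 log units; beyond the scatter) is the only measured change on the acid-bearing ring.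

Compound 4 `Cc1c(OCCCCOc2ccc(C(=O)O)c(Cl)c2)ccc(C(=O)CC(C)C)c1O` brings the change (4-carboxy-3-chlorophenyl in place of 3-carboxyphenyl on an oxygen on a saturated carbon). For the measured compounds named here, no measured step shows the effect of a chlorine on this ring, so the expectation rests on compound 2, whose carboxyl also stands in the 4-position with a small neighbouring substituent and which gave 454 nM, a modestly higher number than compound 3. Compound 4 is therefore expected to land close to compound 2. The step of a 1.8-fold higher number from compound 3 to compound 4 (0.26 log units; within the scatter) is estimated to go upward by a modest amount. The estimate for compound 4 is 400 nM, within a range from 150 nM to 1100 nM.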

Compound 4, half-maximal effective concentration: 151 nM
Beside the measured number, compound 4's estimate is 2.6-fold (0.42 log units) above it; low and high end bracket the measured number.
By their numbers in this assay, from the lowest: compounds 4 and 3 (each within the scatter of the next); then compound 2.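

Replacing 3-carboxyphenyl with 4-carboxy-3-chlorophenyl, on an oxygen on a saturated carbon, gives a 1.5-fold lower number from compound 3 to compound 4 (0.17 log units; within the scatter) in this assay and so leaves compound 3 and compound 4 indistinguishable, which shows that this place accepts a ring carrying both a chlorine and a carboxylic acid named at a different ring position. The comparison with 5-carboxy-2-methylphenyl at the same place gives a 3.0-fold lower number from compound 2 to compound 4 (0.48 log units; beyond the scatter) and is a clearer separation, so the choice of substituted ring can matter here, although this modest step rests on a single pair. Nothing among the data gives a measured reason for either step.

As far as these compounds go, because compound 4 differs from compound 3 in both the chlorine and the named carboxyl position, the part played by each change on its own remains open, and 4-carboxyphenyl would be needed to separate them. From the compounds shown here alone, it is also open how the numbers would respond to a bromine or a methoxy group in place of the chlorine, or to an amide in place of the carboxylic acid.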